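Hydrogen for methyl on a ring nitrogen: two pairs compared

This account rests on a few compounds, and the source may have more. Where it says the series, first, only, none or still open, it means among the compounds named here.

Measured compounds:
compound 1 `Cc1cc2[nH]nc(N)c2c(N2CCCCC2)n1` gives 36%
compound 2 `Cc1cc2c(c(N)nn2C)c(N2CCCCC2)n1` gives 6%
compound 3 `Cc1cc2c(cn1)c(N)nn2C` gives 0%

All three were run in an assay on isolated protein for inhibition of RAC-alpha serine/threonine-protein kinase (Homo sapiens), read by mobility shift assay, tested at 30 uM; on this read-out lower numbers stand for less inhibition and higher numbers for more inhibition at the one concentration tested (going by the name of the read-out). From compound 2 to compound 1 the change is hydrogen in place of methyl on an aromatic nitrogen and the step is a number 30 percentage points higher from compound 2 to compound 1 (beyond the scatter). The cores of compound 2 and compound 3 differ by hydrogen in place of piperidin-1-yl on an aromatic carbon, with a step of a number 6 percentage points lower from compound 2 to compound 3 (within the scatter). Compound 4 `Cc1cc2[nH]nc(N)c2cn1` has not been measured. It differs from compound 3 by hydrogen in place of methyl on an aromatic nitrogen, the same change as from compound 2 to compound 1, described at the same place in the same words. The step expected from compound 3 to compound 4 is a number 15 percentage points higher from compound 3 to compound 4 (beyond the scatter). Going by the values given here, it is set smaller than the earlier one because a number 30 percentage points higher from compound 2 to compound 1 (beyond the scatter) was seen on a core carrying piperidin-1-yl, which compound 3 lacks, and only one precedent exists. Compound 4 is therefore expected at 15%, with a range from 0% to 35%.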

Compound 4, a percentage reported as inhibition, at one concentration (the size of the read-out at that concentration, not a potency): -1%
Compound 4: middle estimate off by 16 percentage points, on the high side; measured number below the stated range.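

In this assay, hydrogen in place of methyl on an aromatic nitrogen comes with a number 1 percentage points lower from compound 3 to compound 4 (within the scatter). The change therefore does not carry over as a fixed step between these two cores: the same change on two cores in this assay, a number 30 percentage points higher (beyond the scatter) from compound 2 to compound 1 and a number 1 percentage points lower (within the scatter) from compound 3 to compound 4, 31 percentage points apart, beyond the scatter of two such steps

Going by these compounds alone, with a single pair on each core, this shows only that the step depends on the core; it does not show why, or how the change would behave on any third core. From the compounds shown here alone, it remains open whether the step seen on the core of compound 1 requires piperidin-1-yl or would also appear with a morpholine ring or a dimethylamino group in its place. Also open, going by these compounds, is how an ethyl group or a longer chain on that ring nitrogen would read on either core.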